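From tert-butyl to cyclopentyl on the shared core

A few compounds are considered here, and "the series" means these few. Any claim that something is new, unique, unknown or untested is made for them only; others in the source may bear on it.

Compound 1 `CCCCn1cc(C(=O)O)c(=O)c2c(O)c(Cc3cccc(Cl)c3F)ccc21`: 20000 nM
Compound 2 `CC(C)n1cc(C(=O)O)c(=O)c2c(O)c(Cc3cccc(Cl)c3F)ccc21`: 26500 nM
Compound 3 `CC(C)(C)n1cc(C(=O)O)c(=O)c2c(O)c(Cc3cccc(Cl)c3F)ccc21`: 400000 nM

In an ADME assay on C8166 cells (Homo sapiens) for cytotoxicity, read by MTT assay (on this read-out lower numbers stand for higher toxicity in this test and higher numbers for lower toxicity in this test), compound 3 has the highest number of the three at 400000 nM and stands clearly apart from the other two. Compound 4 `O=C(O)c1cn(C2CCCC2)c2ccc(Cc3cccc(Cl)c3F)c(O)c2c1=O` differs from compound 3 only on an aromatic nitrogen: cyclopentyl in place of tert-butyl on an aromatic nitrogen. Three measured steps change the group at this same place. Two are large: a 20-fold higher number from compound 1 to compound 3 (1.30 log units; beyond the scatter) and a 15-fold higher number from compound 2 to compound 3 (1.18 log units; beyond the scatter). The third, a 1.3-fold higher number from compound 1 to compound 2 (0.12 log units; within the scatter), stays within the scatter. Only the tert-butyl compound stands apart so far, so removing tert-butyl is expected to bring a large step down, towards compound 1 and compound 2. The expected change is an 11-fold lower number from compound 3 to compound 4 (1.06 log units; beyond the scatter). Compound 4 is estimated at 35000 nM, with an expected range from 12000 nM to 120000 nM.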

Compound 4, half-maximal cytotoxic concentration: 12400 nM
Estimate against measurement, compound 4: 2.8-fold (0.45 log units) above, and the stated range covers the measured number.
By their numbers in this assay, from the lowest: compounds 4, 1 and 2 (each within the scatter of the next, the first and the last beyond it); then compound 3.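

In this assay, the large step, a 32-fold lower number from compound 3 to compound 4 (1.51 log units; beyond the scatter), shows that a five-membered ring on this aromatic nitrogen does not share the tert-butyl result, so among these four groups the high number stays with tert-butyl alone. Cyclopentyl instead falls among the open-chain groups, with a 1.6-fold lower number from compound 1 to compound 4 (0.21 log units; within the scatter) and a modest 2.1-fold lower number from compound 2 to compound 4 (0.33 log units; beyond the scatter). Nothing measured here explains why tert-butyl stands apart. The compounds shown leave open whether other groups on this nitrogen, such as a cyclopropyl ring, a phenyl ring or a chain ending in an amine, would stay near compound 1 or approach compound 3.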